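Aryl variation at the benzylic carbon in the series

A few compounds are considered here, and "the series" means these few. Any claim that something is new, unique, unknown or untested is made for them only; others in the source may bear on it.

Measured so far:
compound 1 `Cc1ccnc(NC(c2ccc(F)cc2)c2ccc3cccnc3c2O)c1` — 140 nM
compound 2 `Cc1ccnc(NC(c2ccc(OCc3ccccc3)cc2)c2ccc3cccnc3c2O)c1` — 620 nM

In an assay for inhibition of protein disulfide-isomerase (Homo sapiens), with a stated time of 1 h (on this read-out higher numbers stand for weaker inhibition and lower numbers for stronger inhibition), compound 1 gives 140 nM, the lowest of the two numbers. Compound 2 gives 620 nM. Going by the values given here, the one measured step, a 4.4-fold higher number from compound 1 to compound 2 (0.65 log units; beyond the scatter), is the only change in this region so far.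

Compound 3 `Cc1ccnc(NC(c2cc(C)ccc2C)c2ccc3cccnc3c2O)c1` carries 2,5-dimethylphenyl in place of 4-fluorophenyl on a saturated chain carbon bound to an aromatic carbon and a nitrogen on an aromatic ring. Among the compounds with values here, no measured step covers this exchange directly; the step from compound 1 to compound 2 only shows that altering the same phenyl raised the number modestly, so a modest step in the same direction is expected for compound 3, a 2.0-fold higher number from compound 1 to compound 3 (0.30 log units; within the scatter). Compound 3 is therefore estimated at 280 nM (90 nM to 900 nM).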

Compound 3, half-maximal inhibitory concentration: > 40000 nM
Compound 3 gave a limit, no number; the forecaster's own chance of this, stated with the estimate: 5%; at least 140-fold (2.15 log units) between middle value and limit.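

In this assay, exchanging 4-fluorophenyl for 2,5-dimethylphenyl gives an at least 280-fold higher number from compound 1 to compound 3 (2.45 log units; beyond the scatter), a far larger step than a 4.4-fold higher number from compound 1 to compound 2 (0.65 log units; beyond the scatter). The value of compound 3 is a limit of the assay, not a number: the limit of > 40000 nM in this assay, at which 1 of the 3 values shown sits. Aryl exchange at this carbon can therefore do more than shift the number modestly, and the size of the added group alone does not track the result, since compound 2 with benzyloxy still gives 620 nM.

The compounds shown do not separate the contributions of the two methyl groups of 2,5-dimethylphenyl. On these data alone, whether a pyridyl group at this carbon keeps a measurable value also remains open.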